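Thiourea series against a breast cancer cell line: one ring change

The source may report more compounds than this note shows. Statements on the series, on what has been measured and on what is new or still open speak of the compounds shown alone.

Measured so far:
compound 1, `Nc1ccccc1NC(=O)c1ccc(NC(=O)NCc2ccc(Cl)nc2)cc1`: 34000 nM
compound 2, `Cc1ccc(CNC(=S)Nc2ccc(C(=O)Nc3ccccc3N)cc2)cn1`: 63000 nM
compound 3, `Nc1ccccc1NC(=O)c1ccc(Cn2cc(-c3ccc(NC(=O)NCc4cccnc4)cc3)nn2)cc1`: > 100000 nM

In a functional assay on MDA-MB-231 cells (Homo sapiens) for cytotoxicity, read by MTT assay, with a stated time of 72 h (a higher number here means a weaker inhibitor, a lower number a stronger inhibitor), compound 2 gives 63000 nM. Of the two numbers recorded, this is the higher one; compound 1 sits nearest, and the gap between the two lies within the usual scatter of the measurement, so no order between them can be stated. Compound 3 gives only a limit in this assay, > 100000 nM, and no number. One of three values thus stands at that limit (the limit of > 100000 nM in this assay, at which 1 of the 3 values shown sits).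

The unmeasured compound 4, `Nc1ccccc1NC(=O)c1ccc(NC(=S)NCc2cncc(F)c2)cc1`, shares everything with compound 2 except one ring: 5-fluoropyridin-3-yl in place of 6-methylpyridin-3-yl on a saturated chain carbon bound to an amide-type nitrogen. Within the data shown here, no pair of measured compounds differs by a single change, so no measured step guides the expectation. Given the small size of the exchange, the step from compound 2 to compound 4 is expected to lie within the scatter, in no firm direction, which is what a 1.1-fold lower number from compound 2 to compound 4 (0.06 log units; within the scatter) expresses. Compound 4 is therefore estimated at 55000 nM in this assay, with a range from 25000 nM to 100000 nM.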

Compound 4, half-maximal inhibitory concentration: 85000 nM
For compound 4 the middle estimate is 1.5-fold (0.19 log units) below the measured one; the measured number falls inside the stated range.
By their numbers in this assay, from the lowest: compounds 1, 2 and 4 (each within the scatter of the next, the first and the last beyond it). At a limit, above all of these: compound 3.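

Among these compounds, the exchange of 6-methylpyridin-3-yl for 5-fluoropyridin-3-yl on a saturated chain carbon bound to an amide-type nitrogen is the first single change that can be read, and in this assay it amounts to a 1.3-fold higher number from compound 2 to compound 4 (0.13 log units; within the scatter). At this position, then, the two substituted pyridine rings cannot be told apart: compound 2 gives 63000 nM and compound 4 gives 85000 nM, so the thiourea keeps a number of the same order with either ring and no ranking of the two can be stated. Nothing measured in the compounds shown bears on why this exchange leaves the number within the scatter.

One step between two closely matched rings cannot show whether this position responds to change at all, and a pyridine ring carrying an amine or a methoxy group, a plain phenyl ring, or a longer chain in place of the methyl link could test that. Among the compounds shown here, the part played by the thiourea itself also stays open, since no measured pair sets it against a urea with all else equal.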